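Inverting one ring stereocentre on a fluorinated nucleoside analogue

A few compounds are considered here, and "the series" means these few. Any claim that something is new, unique, unknown or untested is made for them only; others in the source may bear on it.

Compound 1, `Nc1ncnc2c1ncn2[C@H]1CS[C@@H](CO)O1`: in a functional assay on Vero cells (Chlorocebus sabaeus) for inhibition (a lower number here means a stronger inhibitor, a higher number a weaker inhibitor), compound 1 reaches only the limit > 100000 nM.
Compound 2, `Nc1ncnc2c1ncn2[C@@H]1CS[C@@H](CO)O1`: compound 2 likewise gives only the limit > 100000 nM in this assay.
Compound 3, `Nc1nc(F)nc2c1ncn2[C@H]1CS[C@@H](CO)O1`: compound 3 gives 5600 nM in this assay.

Among the compounds with values here, compound 3 holds the only real number among the three; the other two values are limits of the assay, not numbers. Compound 3 is obtained from compound 1 by an at least 17-fold lower number from compound 1 to compound 3 (1.25 log units; beyond the scatter), a step that is large and points to a stronger inhibitor. The step from compound 1 to compound 2 is a change of configuration alone, and a step that the two limits leave unreadable from compound 1 to compound 2 because of the limit of > 100000 nM in this assay, at which 2 of the 3 values shown sit, so it gives no readable size.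

Compound 4, `Nc1nc(F)nc2c1ncn2[C@@H]1CS[C@@H](CO)O1`, is not yet measured. It differs from compound 3 as follows: the two compounds have the same atoms and bonds and differ only in configuration as drawn: 1 of 2 stereo elements differ; a stereocentre at a saturated ring carbon is drawn R in compound 3 and S in compound 4. Within the data shown here, the only measured step of the same kind is the one from compound 1 to compound 2, which is unreadable, as noted, due to the fact that compounds 1 and 2 differ only in the configuration as drawn and the limits. So no direction or size can be taken from the shown steps; the expectation is therefore set near compound 3 with a wide range, leaning toward a weaker inhibitor. Compound 4 is expected at 15000 nM, between 2000 nM and 100000 nM, which means an estimated step of a 2.7-fold higher number from compound 3 to compound 4 (0.43 log units; beyond the scatter).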

Compound 4, half-maximal inhibitory concentration: 45400 nM
Compound 4: the middle estimate sits 3.0-fold (0.48 log units) below what was measured; the range from low to high includes it.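

With fluoro on the aromatic carbon, the ring stereocentre has its first readable effect in this assay: inverting it gives an 8.1-fold higher number from compound 3 to compound 4 (0.91 log units; beyond the scatter), so within this fluoro pair the form drawn R is the stronger inhibitor. Fluoro in place of hydrogen also lowers the number on the form drawn S, with an at least 2.2-fold lower number from compound 2 to compound 4 (0.34 log units; beyond the scatter), which shows that the gain seen earlier is not tied to a single configuration. The two fluoro steps cannot yet be ranked against each other, as the data show only: the same change on two cores in this assay, an at least 17-fold lower number (1.25 log units; beyond the scatter) from compound 1 to compound 3 and an at least 2.2-fold lower number (0.34 log units; beyond the scatter) from compound 2 to compound 4; the limit leaves it open whether they differ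

Going by these compounds, without fluoro, the effect of the same inversion still cannot be read, because both values are limits: the limit of > 100000 nM in this assay, at which 2 of the 4 values shown sit. Also open is whether a chloro group or an amine in place of fluoro on that aromatic carbon would lower the number in the same way, and whether the stereocentre would then matter as much as it does in the fluoro pair.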